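Stomach inhibition in dogs: turning a double bond

The source may hold more compounds than are shown below. What is called first, only, known or untested is meant among the compounds shown, and "the series" means these compounds.

Compound 2 `Cc1nc2c(/C=C\c3ccccc3)cccn2c1N` was tested in a functional assay on the whole organism (stomach) for inhibition, with Canis familiaris (Canis lupus familiaris) as the target, at a dose of 8 mg/kg by the oral route (a lower number here means a weaker effect, a higher number a stronger effect of the compound at the dose given), where compound 2 gives 4%. Its companion compound 1 `Cc1nc2c(/C=C/c3ccccc3)cccn2c1C` gives 3% in the same test, so compound 2 and compound 1 sit together at the low end, within the usual scatter of each other. Compound 3 `Cc1nc2c(/C=C/c3ccccc3)cccn2c1N` is the next compound to be examined. (the two compounds have the same atoms and bonds and differ only in configuration as drawn: 1 of 1 stereo elements differ; a double bond is drawn Z in compound 2 and E in compound 3). Among the compounds with values here, no measured pair here shows what such a change does. For compound 3 the expected step is no change at the digits printed from compound 2 to compound 3 (within the scatter), which is no change beyond the scatter. Compound 3 is therefore estimated at 4%, with a range from 0% to 15%.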

Compound 3, a percentage reported as inhibition, in the whole organism at one dose (the size of the read-out at that dose, not a potency): 6%
Beside the measured number, compound 3's estimate is 2 percentage points below it; low and high end bracket the measured number.
By their numbers in this assay, from the lowest: compounds 1, 2 and 3 (each within the scatter of the next).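

In this assay, turning the double bond gives a number 2 percentage points higher from compound 2 to compound 3 (within the scatter), the first measured view of this change, and it shows no effect beyond the scatter at this dose. This pair tests the double bond alone: the fact that compounds 2 and 3 differ only in the configuration as drawn. With the double bond drawn E, amino in place of methyl on an aromatic carbon gives a number 3 percentage points higher from compound 1 to compound 3 (within the scatter), so this swap also stays within the scatter.

Still open, going by these compounds, is whether a longer chain or a carboxylic acid in place of the amino would give a number beyond the scatter.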